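The source may report more compounds than this note shows. Statements on the series, on what has been measured and on what is new or still open speak of the compounds shown alone.

Compound 1 `[SeH]c1nc(NCc2ccccc2)c2cccnc2n1`: in a functional assay on HTB-54 cells (Homo sapiens) for cytotoxicity, read by MTT assay, with a stated time of 72 h (a higher number here means a weaker inhibitor of growth, a lower number a stronger inhibitor of growth), compound 1 gives > 100000 nM, a limit of the assay rather than a number.
Compound 2 `COc1ccc(CNc2nc(SC)nc3ncccc23)cc1`: in this assay compound 2 gives > 100000 nM, again only a limit.
Compound 3 `CSc1nc(NCCCCCO)c2cccnc2n1`: in this assay compound 3 gives > 100000 nM, likewise a limit.

Compound 3 therefore stands nowhere in particular among these numbers: all three measured compounds sit at the same limit, (the limit of > 100000 nM in this assay, at which 3 of the 3 values shown sit), so no difference between them can be seen. Compound 4 `CSc1nc(NCc2ccccc2)c2cccnc2n1` is not yet measured. It differs from compound 3 by phenyl in place of 4-hydroxybutyl on a saturated chain carbon bound to a nitrogen on an aromatic ring. For the measured compounds named here, with no measured step to lean on, the expected change in this assay is none beyond the scatter, and compound 4 is expected to give 150000 nM (range 30000 nM to 600000 nM), a step that the limit leaves unreadable from compound 3 to compound 4 that most likely ends as another limit.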

Compound 4, concentration for 50% growth inhibition: 5080 nM
Compound 4: the middle estimate sits 30-fold (1.47 log units) above what was measured, outside the stated range (below it).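

In this assay, for the compounds shown here, compound 4 is the first compound here to give a real number rather than a limit: the limit of > 100000 nM in this assay, at which 3 of the 4 values shown sit. Phenyl in place of 4-hydroxybutyl on a saturated chain carbon bound to a nitrogen on an aromatic ring brings an at least 19-fold lower number from compound 3 to compound 4 (1.29 log units; beyond the scatter) and hydrogen in place of methoxy on an aromatic carbon brings an at least 19-fold lower number from compound 2 to compound 4 (1.29 log units; beyond the scatter) and a group of one carbon and one sulfur in place of one selenium atom brings an at least 19-fold lower number from compound 1 to compound 4 (1.29 log units; beyond the scatter). Each of these steps starts from a limit, and each single change separates a measurable compound from one at that limit.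

On these data alone, whether a chloro group in place of that hydrogen, or an amine in place of the phenyl, would lower the number further remains open.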